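Compound 1 to compound 4: fluoro gives way to a larger group

This account rests on a few compounds, and the source may have more. Where it says the series, first, only, none or still open, it means among the compounds named here.

Measured so far in an ADME assay on L6 cells (Rattus norvegicus) for cytotoxicity, read by resazurin assay; on this read-out lower numbers stand for stronger inhibition and higher numbers for weaker inhibition
compound 1 `N=C(N)c1ccc2[nH]c(-c3ccc4nc(-c5ccc(F)cc5)[nH]c4c3)nc2c1` gives 2.48 ug/mL
compound 2 `N=C(N)c1ccc2[nH]c(-c3ccc4nc(-c5ccc(F)c(F)c5)[nH]c4c3)nc2c1` gives 29.8 ug/mL
compound 3 `COc1ccc(-c2nc3ccc(-c4nc5cc(C(=N)N)ccc5[nH]4)cc3[nH]2)cc1OC` gives > 90 ug/mL (a limit of the assay)

Compound 1 holds the lowest number in the set, and its steps to both other compounds lie beyond the scatter. The next compound is compound 4 `COc1ccc(Oc2ccc(-c3nc4ccc(-c5nc6cc(C(=N)N)ccc6[nH]5)cc4[nH]3)cc2)cc1OC`, and the change from compound 1 is 3,4-dimethoxyphenoxy in place of fluoro on an aromatic carbon with 3,4-dimethoxyphenoxy in place of fluoro on an aromatic carbon.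

Among the measured compounds shown here, no measured step makes this exact change, so the evidence is indirect. Both steps away from compound 1 raised the number and both were large: a 12-fold higher number from compound 1 to compound 2 (1.08 log units; beyond the scatter) with one added fluoro, and an at least 36-fold higher number from compound 1 to compound 3 (1.55 log units; beyond the scatter) with 3,4-dimethoxyphenyl in place of 4-fluorophenyl. The last measured step, an at least 3.0-fold higher number from compound 2 to compound 3 (0.48 log units; beyond the scatter) as the change, points the same way.

A higher number is therefore expected for compound 4 in this assay as well, and the expected step is large. The estimated change is an 8.1-fold higher number from compound 1 to compound 4 (0.91 log units; beyond the scatter) in size. For the measured compounds named here, no measured compound carries a phenoxy group, so the range is kept wide. Compound 4 is expected at 20 ug/mL within an estimated range of 4 ug/mL to 90 ug/mL at this stage.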

Compound 4, half-maximal inhibitory concentration: 29.4 ug/mL
Compound 4: the middle estimate sits 1.5-fold (0.17 log units) below what was measured; the measured number falls inside the stated range.
By their numbers in this assay, from the lowest: compound 1; then compounds 4 and 2 (each within the scatter of the next). At a limit, above all of these: compound 3.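

In this assay, the aromatic carbon that carries fluoro in compound 1 tolerates a much larger group while still giving a number within the assay's range: a 12-fold higher number from compound 1 to compound 4 (1.07 log units; beyond the scatter). This step is large, as is a 12-fold higher number from compound 1 to compound 2 (1.08 log units; beyond the scatter), so within these two changes, both the 3,4-dimethoxyphenoxy group and one added fluoro move the number well beyond the scatter. Compound 3 is the only compound at a limit of the assay, and its value is a limit rather than a number: the limit of > 90 ug/mL in this assay, at which 1 of the 4 values shown sits.

The compounds shown do not separate the contribution of the phenoxy oxygen and ring from that of the two methoxy groups. An unsubstituted phenoxy, a simple amine or a carboxylic acid at this carbon would test whether the higher number needs the full 3,4-dimethoxyphenoxy group.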